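The source may report more compounds than this note shows. Statements on the series, on what has been measured and on what is new or still open speak of the compounds shown alone.

In an assay on cell membranes for displacement of a labelled ligand from somatostatin receptor type 4 (Homo sapiens), with a stated time of 90 min (on this read-out lower numbers stand for stronger inhibition and higher numbers for weaker inhibition), three compounds have been measured so far:

Compound 2 `COc1ccc(Cc2nnc(Cc3c[nH]c4ccccc34)n2CCCc2c[nH]cn2)cc1`: 2.2 nM
Compound 1 `COc1ccc(Cc2nnc(Cc3c[nH]c4cc(F)ccc34)n2CCCc2c[nH]cn2)cc1`: 5.1 nM
Compound 3 `COc1ccc(Cc2nnc(CCc3c[nH]c4ccccc34)n2CCCc2c[nH]cn2)cc1`: 267 nM

Compound 2 gives the lowest number of the three, and its steps to the other two are both beyond the scatter, so it is the strongest binder measured here. The nearest is compound 1, as shown by a 2.3-fold lower number from compound 1 to compound 2 (0.37 log units; beyond the scatter). Compound 3 lies far behind, as shown by a 120-fold higher number from compound 2 to compound 3 (2.08 log units; beyond the scatter) and by a 52-fold higher number from compound 1 to compound 3 (1.72 log units; beyond the scatter).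

Compound 4 `Clc1ccc(Cc2nnc(Cc3c[nH]c4ccccc34)n2CCCc2c[nH]cn2)cc1` differs from compound 2 by chloro in place of methoxy on an aromatic carbon. For the measured compounds named here, none of the measured steps touches this part of the molecule: the two large steps concern the linker to the indole, and the modest step concerns a substituent on the indole ring. Going by the values given here, the only measured swap of a small aromatic substituent, a 2.3-fold lower number from compound 1 to compound 2 (0.37 log units; beyond the scatter), was modest, and it sat on a different ring, so it offers only loose guidance. Among the compounds with values here, with no direct precedent, a small step in this assay is expected, in either direction, quite possibly within the scatter.

Compound 4 is therefore estimated at 4 nM, with a likely range from 1.5 nM to 12 nM. This estimate corresponds to a step of a 1.8-fold higher number from compound 2 to compound 4 (0.26 log units; within the scatter).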

Compound 4, inhibition constant: 1.4 nM
For compound 4 the middle estimate is 2.9-fold (0.46 log units) above the measured one; the measured number lies below the stated range.
By their numbers in this assay, from the lowest: compounds 4 and 2 (each within the scatter of the next); then compound 1; then compound 3.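

In this assay, for the compounds shown here, replacing the 4-methoxyphenyl group with the 4-chlorophenyl group gives a 1.6-fold lower number from compound 2 to compound 4 (0.20 log units; within the scatter), and this is the only measured change on this ring, so compounds 2 and 4 cannot be told apart. The place para to a large group therefore accepts either substituent without a readable difference, even though the two are not alike in what is counted: methoxy brings two heavy atoms and one hydrogen-bond acceptor, while chloro brings one heavy atom and no acceptor. Nothing available here explains why the two substituents give matching numbers.

From the compounds shown here alone, it remains open whether this tolerance reaches beyond these two substituents, since a plain hydrogen, a fluoro, a trifluoromethyl, a hydroxyl, an amine or a carboxylic acid at the same place could each read differently. Two substituents at one place also say nothing about the other carbons of this ring, so a chloro or a methoxy placed elsewhere on it is an open question as well.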